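Cytotoxicity notes: three measured analogues and a fourth

This account rests on a few compounds, and the source may have more. Where it says the series, first, only, none or still open, it means among the compounds named here.

Three compounds have numbers in a functional assay on PC-3 cells (Homo sapiens) for cytotoxicity, read by MTT assay, with a stated time of 48 h; on this read-out lower numbers stand for stronger inhibition and higher numbers for weaker inhibition. Compound 1 `CC1=NN(C(=O)COc2ccc(Cl)cc2)C(c2cc(Br)cc(Br)c2O)C1` gives 40200 nM, and compound 2 `CC1=NN(S(=O)(=O)c2ccc([N+](=O)[O-])cc2)C(c2cc(Br)cc(Br)c2O)C1` gives 50000 nM. Compound 3 `Cc1ccc(C(=O)N2N=C(c3cc4ccccc4oc3=O)CC2c2ccccc2)cc1` gives 13200 nM, the lowest of the three; its gaps to compound 1 and to compound 2 both lie beyond the usual scatter, so on these numbers compound 3 is the most active of the set.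

Compound 4 `O=C(CCl)N1N=C(c2cc3ccccc3oc2=O)CC1c1ccccc1` differs from compound 3 in one place: chloromethyl in place of 4-methylphenyl on a carbonyl carbon. For the measured compounds named here, no pair of measured compounds shows this kind of exchange, so the size and direction of the step cannot be read from the numbers in hand. The expectation is therefore a cautious one: the step from compound 3 to compound 4 is estimated as a 1.3-fold lower number from compound 3 to compound 4 (0.12 log units; within the scatter), that is, no change beyond the scatter in this assay. Compound 4 is accordingly expected at 10000 nM, with a range from 3000 nM to 40000 nM.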

Compound 4, half-maximal inhibitory concentration: 2980 nM
Compound 4: middle estimate off by 3.4-fold (0.53 log units), on the high side; the measured number lies below the stated range.
By their numbers in this assay, from the lowest: compound 4; then compound 3; then compounds 1 and 2 (each within the scatter of the next).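

In this assay, for the compounds shown here, the group on a carbonyl carbon whose other neighbour is an amide-type nitrogen in a ring proves able to move the number: chloromethyl in place of 4-methylphenyl gives a 4.4-fold lower number from compound 3 to compound 4 (0.65 log units; beyond the scatter) and is the first step that can be read from a single change. The 4-methylphenyl ring, with its 7 heavy atoms, is therefore not required for activity on this core, since chloromethyl, with 2 heavy atoms and no ring, gives the lower number. No measurement bears on the reason for this step.

Whether the chlorine or the shorter group accounts for the step stays open, and plain methyl, aminomethyl or a longer chloroalkyl chain would separate the two. Going by these compounds, whether the same exchange carries over to the core of compound 1 also stays open.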